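Ring Amine in Place of Dimethylamino: Expected Cytotoxicity

The source may report more compounds than this note shows. Statements on the series, on what has been measured and on what is new or still open speak of the compounds shown alone.

Compound 1 `CN(C)c1ccc(-c2nc3c(s2)C(O)CNC3)cc1` was tested in a functional assay on HCT-116 cells (Homo sapiens) for cytotoxicity, read by sulforhodamine B assay, with a stated time of 2 days (a higher number here means a weaker inhibitor, a lower number a stronger inhibitor), where compound 1 gives 1330 nM. Going by the values given here, this is the higher of the two numbers measured so far; compound 2 `OCc1cc(N2CCCC2)ccc1-c1nc2c(s1)C(O)CCC2` gives 42 nM in this assay, a far lower number, yet compound 2 differs from compound 1 in more than one place, so no single change accounts for that gap. Compound 3 `OC1CNCc2nc(-c3ccc(N4CCCC4)cc3)sc21` keeps the core of compound 1 and alters one group only: pyrrolidin-1-yl in place of dimethylamino on an aromatic carbon. Among the compounds with values here, no measured pair isolates this change. Compound 3 is expected to give a somewhat lower number, a moderate step of a 2.7-fold lower number from compound 1 to compound 3 (0.42 log units; beyond the scatter), with an estimated 500 nM and a range from 150 nM to 1500 nM.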

Compound 3, half-maximal inhibitory concentration: 730 nM
For compound 3 the middle estimate is 1.5-fold (0.16 log units) below the measured one, within the range that was stated.
By their numbers in this assay, from the lowest: compound 2; then compounds 3 and 1 (each within the scatter of the next).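

Going by these compounds alone, the first pair to isolate this change gives a 1.8-fold lower number from compound 1 to compound 3 (0.26 log units; within the scatter) in this assay, so pyrrolidin-1-yl and dimethylamino cannot be told apart at this position, on an aromatic carbon para to a large group. Closing the two carbons of dimethylamino into a larger, five-membered ring therefore brings no measurable gain or loss in this cell test. Nothing available accounts for this similarity.

Still open, as far as these compounds go, is how other groups at the same position would read, such as piperidin-1-yl, morpholin-4-yl or a simple primary amine. A single pair also cannot show whether the result holds on a different core.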